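The compounds below may be only part of what the source reports. "The series", "measured", "known", "first", "only" and "open" are said of these compounds alone.

Measured so far:
Compound 1 `COc1ccc(-c2noc(-c3ccncc3)n2)cc1OC1CCCC1`: > 1000000 nM (a limit)
Compound 2 `COc1ccc(-c2noc(-c3ccc(F)cc3)n2)cc1OC1CCCC1`: 87900 nM
Compound 3 `COc1cc(-c2noc(-c3ccncc3)n2)ccc1OCc1ccccc1`: > 1000000 nM (a limit)

In a functional assay on LNCaP cells (Homo sapiens) for antiproliferative activity, read by MTT assay, with a stated time of 24 h (a lower number here means a stronger inhibitor, a higher number a weaker inhibitor), compound 1 has no exact number, only the limit > 1000000 nM. Compound 3 also reaches only a limit, and together they make up (the limit of > 1000000 nM in this assay, at which 2 of the 3 values shown sit). Compound 2 is the only one of the three with an exact value, 87900 nM.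

The next compound, compound 4 `COc1ccc(-c2noc(-c3ccc(Cl)cc3)n2)cc1OC1CCCC1`, keeps the core of compound 1 but changes one group: 4-chlorophenyl in place of pyridin-4-yl on an aromatic carbon. In words, 4-chlorophenyl replaces pyridin-4-yl on an aromatic carbon, so a six-membered aromatic ring of carbon only enters.

Going by the values given here, one measured step bears on this change: an at least 11-fold lower number from compound 1 to compound 2 (1.05 log units; beyond the scatter). There, 4-fluorophenyl took the place of pyridin-4-yl, and the step was large and beyond the scatter. From the compounds shown here alone, its true size remains open, since one end of it is a limit. Among the compounds with values here, with only this step as a guide, a similar move toward a lower number is expected for the new swap.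

The expected change is an at least 12-fold lower number from compound 1 to compound 4 (1.09 log units; beyond the scatter), a large step toward stronger inhibition.

The estimate for compound 4 is 80000 nM, with an expected range of 25000 nM to 280000 nM.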

Compound 4, half-maximal inhibitory concentration: 20800 nM
Estimate against measurement, compound 4: 3.8-fold (0.59 log units) above, outside the stated range (below it).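

In this assay, 4-chlorophenyl in place of pyridin-4-yl gives an at least 48-fold lower number from compound 1 to compound 4 (1.68 log units; beyond the scatter), so compound 2 is no longer the only case in which a six-membered aromatic ring of carbon only, at this place on the core, gives a measurable value. The new result also shows that the atom on that ring matters, not just the loss of the ring nitrogen: chloro in place of fluoro gives a 4.2-fold lower number from compound 2 to compound 4 (0.63 log units; beyond the scatter), a modest step but one beyond the scatter. Compound 1 has only a limit, so the true size of the first step stays open, and it can be read only as a minimum: the limit of > 1000000 nM in this assay, at which 2 of the 4 values shown sit.

The compounds shown compare just fluoro and chloro on this ring, and leave open how a bromo, a methoxy, a nitrile or an amine in the same spot would read. They also leave open whether 4-chlorophenyl would bring a similar change on the core of compound 3, which has only a limit here.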